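This account rests on a few compounds, and the source may have more. Where it says the series, first, only, none or still open, it means among the compounds named here.

Compound 1 `O=C1N=C(N2N=C(c3ccccc3)CC2c2ccccc2O)S/C1=C1/C(=O)Nc2ccccc21` is the weaker of two measured compounds in a functional assay on cells (Cancer cell lines, Homo sapiens) for cytotoxicity, read by sulforhodamine B assay, with a stated time of 48 h (a lower number here means a stronger inhibitor of growth, a higher number a weaker inhibitor of growth), where compound 1 gives 17800 nM. Among the compounds with values here, the other measured compound, compound 2 `O=C1N=C(N2N=C(c3ccccc3)CC2c2ccccc2O)S/C1=C1/C(=O)Nc2ccc(Br)cc21`, gives 630 nM in this assay, and the single measured step of a 28-fold lower number from compound 1 to compound 2 (1.45 log units; beyond the scatter) shows what one change elsewhere in the molecule can do.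

Compound 3 `COc1ccc(C2CC(c3ccccc3)=NN2C2=NC(=O)/C(=C3\C(=O)Nc4ccccc43)S2)cc1` changes compound 1 in a different place: 4-methoxyphenyl in place of 2-hydroxyphenyl on a saturated ring carbon. Within the data shown here, no measured step touches this part of the shared core, so the step from compound 1 to compound 2 gives no direct guide to it, and the range for compound 3 must be wide. In the absence of any bearing step, compound 3 is expected to stay near compound 1, with a step of a 1.2-fold lower number from compound 1 to compound 3 (0.07 log units; within the scatter) not expected to reach beyond the scatter. Compound 3 is therefore estimated at 15000 nM in this assay, within a range from 4000 nM to 60000 nM.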

Compound 3, concentration for total growth inhibition: 4270 nM
Compound 3: the middle estimate sits 3.5-fold (0.55 log units) above what was measured; the measured number falls inside the stated range.
By their numbers in this assay, from the lowest: compound 2; then compound 3; then compound 1.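

Changing the group on the saturated ring carbon next to the ring nitrogen does register in the cell read-out: 4-methoxyphenyl in place of 2-hydroxyphenyl gives a 4.2-fold lower number from compound 1 to compound 3 (0.62 log units; beyond the scatter) in this assay, so this part of the shared core also affects the number, though the step is smaller than the one for bromo, a 28-fold lower number from compound 1 to compound 2 (1.45 log units; beyond the scatter). The swap changes several things at once: the oxygen group differs, its place on the phenyl ring differs, and the count of hydrogen-bond donors goes from 1 to 0, so this single step cannot separate these changes. Nothing available explains the size of this step.

The compounds shown leave open how a plain phenyl group, or a phenyl carrying an amine or a carboxylic acid, would read at this carbon. They also leave open whether 4-methoxyphenyl and the bromo of compound 2 would add up in one molecule.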